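Fluoro in place of chloro on compound 2

The compounds below may be only part of what the source reports. "The series", "measured", "known", "first", "only" and "open" are said of these compounds alone.

Measured in a functional assay on NALM-6 cells (Homo sapiens) for cytotoxicity, read by luminescence and CellTiter-Glo, with a stated time of 3 days; a higher number here means a weaker inhibitor, a lower number a stronger inhibitor
- compound 1 (`O=C(Nc1cc(F)cc(F)c1)c1ccc2cccnc2c1O`) gives 310 nM
- compound 2 (`O=C(Nc1ccc(C(F)(F)F)cc1)c1cc(Cl)ccc1O`) gives 1210 nM
- compound 3 (`O=C(Nc1cc(C(F)(F)F)cc(C(F)(F)F)c1)c1ccc(-c2ccccc2)cc1O`) gives 1580 nM

Compound 2 at 1210 nM is level, within the scatter, with compound 3 at 1580 nM, while compound 1 at 310 nM shows a clearly lower number. Compound 4 (`O=C(Nc1ccc(C(F)(F)F)cc1)c1cc(F)ccc1O`) carries fluoro in place of chloro on an aromatic carbon, para to a hydroxy group (fluoro in place of chloro on an aromatic carbon). Going by the values given here, no measured pair tests this change, so the direction is a judgement with little support. The expected result is a small move to a higher number, probably not beyond the scatter, a 1.6-fold higher number from compound 2 to compound 4 (0.20 log units; within the scatter). Compound 4 is expected at 1900 nM, with an estimated range from 800 nM to 4500 nM.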

Compound 4, half-maximal inhibitory concentration: 2090 nM
The estimate for compound 4 lay 1.1-fold (0.04 log units) below the measured number; the measured number falls inside the stated range.
By their numbers in this assay, from the lowest: compound 1; then compounds 2, 3 and 4 (each within the scatter of the next).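

Going by these compounds alone, this is the first matched pair: in this assay, fluoro in place of chloro on the aromatic carbon para to a hydroxy group gives a 1.7-fold higher number from compound 2 to compound 4 (0.24 log units; within the scatter), so this assay does not separate the two halogens at this position. No measured evidence bears on the reading of this pair. As far as these compounds go, whether an amine or a carboxylic acid on this carbon would move the number beyond the scatter remains open. One pair also leaves open whether the same exchange reads alike on other aromatic carbons.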